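A Second Chloro on the Shared Core of Compound 1

The compounds below may be only part of what the source reports. "The series", "measured", "known", "first", "only" and "open" are said of these compounds alone.

Measured so far: compound 1 `ClCc1ccccc1Cn1cnc2ncnc(Cl)c21` with 24000 nM, and compound 2 `Nc1nc(Cl)c2ncn(Cc3cccc(CCl)c3)c2n1` with 27500 nM.

In a functional assay on A549 cells (Homo sapiens) for cytotoxicity, read by sulforhodamine B assay, with a stated time of 48 h (on this read-out lower numbers stand for stronger inhibition of growth and higher numbers for weaker inhibition of growth), compound 1 gives 24000 nM, the lowest of the two numbers shown, and compound 2 gives 27500 nM, a number within the scatter of that of compound 1. Compound 3 `ClCc1ccccc1Cn1cnc2nc(Cl)nc(Cl)c21` has not yet been measured; it differs from compound 1 by chloro in place of hydrogen on an aromatic carbon. Among the compounds with values here, no measured pair shows this change, so no step size is known from the data. Compound 3 is expected to stay close to compound 1, the step of a 1.2-fold lower number from compound 1 to compound 3 (0.08 log units; within the scatter) not beyond the scatter. For compound 3 the estimated value in this assay is 20000 nM, in a range from 6000 nM to 60000 nM.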

Compound 3, concentration for total growth inhibition: 5750 nM
For compound 3 the middle estimate is 3.5-fold (0.54 log units) above the measured one; measured number below the stated range.
By their numbers in this assay, from the lowest: compound 3; then compounds 1 and 2 (each within the scatter of the next).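

In this assay, chloro in place of hydrogen on an aromatic carbon between two ring nitrogen atoms gives a 4.2-fold lower number from compound 1 to compound 3 (0.62 log units; beyond the scatter). Within the data shown here, this is the first step that can be read on the shared core, and it shows that this position is not silent: a single added chlorine moves the number by a modest step. Nothing measured here accounts for that step. As far as these compounds go, whether a methyl or a methoxy group at the same place would give a similar step stays open. So does whether fluoro or bromo would match chloro there.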